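The compounds below may be only part of what the source reports. "The series", "measured", "known", "first", "only" and "open" are said of these compounds alone.

Compound 1 `C=CC1=C(C(=O)NCc2ccccc2F)C(c2ccc(F)cc2)OC1` — in a functional assay on HeLa cells (Homo sapiens) for cytotoxicity, read by MTT assay, with a stated time of 24 h (on this read-out higher numbers stand for weaker inhibition and lower numbers for stronger inhibition), compound 1 gives > 100000 nM, which is a limit of the assay and not a number.
Compound 2 `C=CC1=C(C(=O)Nc2ccc(OCC)cc2)C(c2ccc(OC)cc2)OC1` — in this assay compound 2 gives > 100000 nM, again only a limit.
Compound 3 `C=CC1=C(C(=O)Nc2ccccc2OC)C(c2ccc(Cl)c(Cl)c2)OC1` — in this assay compound 3 gives > 100000 nM, again only a limit.

On the numbers shown, compound 1 has no place of its own: only a limit is known for it, and the two further values shown are limits as well, all three sitting at the limit of > 100000 nM in this assay, at which 3 of the 3 values shown sit. Compound 4 `C=CC1=C(C(=O)NCCCCC)C(c2ccc(F)cc2)OC1` has not yet been measured. It differs from compound 1 by butyl in place of 2-fluorophenyl on a saturated chain carbon bound to an amide-type nitrogen; cut one bond further out, the same change reads 2-fluorobenzyl to pentyl. Among the compounds with values here, no pair of measured compounds differs in one place, so no measured step size is available. The step from compound 1 to compound 4 is expected to be none beyond the scatter, estimated as a number no higher from compound 1 to compound 4 (the limit leaves the size open), because the three values shown all fall at the limit of > 100000 nM in this assay, at which 3 of the 3 values shown sit. Compound 4 is therefore expected at 100000 nM, within a range from 30000 nM to 300000 nM, and most likely reported again only as a limit.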

Compound 4, half-maximal inhibitory concentration: > 100000 nM
Compound 4 ended at the assay's limit; the forecaster's own chance of this, stated with the estimate: 80%; the middle value lies on the limit itself.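

Compound 1 and compound 4 are both reported only as limits in this assay, so the step between them cannot be read. The compounds shown leave open how far each lies past that limit, and whether pentyl in place of 2-fluorobenzyl changes anything at all.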